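Chain extension on the shared core: compound 2 to compound 3

A few compounds are considered here, and "the series" means these few. Any claim that something is new, unique, unknown or untested is made for them only; others in the source may bear on it.

Compound 1 `Cc1ccc(OCc2nn3c(Cn4nnc5ccccc54)nnc3s2)cc1` and compound 2 `Fc1cccc(-c2nn3c(Cc4ccccc4)nnc3s2)c1` share a core. In an assay for inhibition of histone-lysine N-methyltransferase, H3 lysine-79 specific (Homo sapiens), with stated times of 15 min and 120 min, tested at 50 uM (on this read-out lower numbers stand for less inhibition and higher numbers for more inhibition at the one concentration tested (going by the name of the read-out)), compound 1 gives 52%. In this assay compound 2 gives 33%, the lower of the two numbers, sitting below compound 1 by a gap beyond the usual scatter. Compound 3 `Fc1cccc(-c2nn3c(CCc4ccccc4)nnc3s2)c1` is not yet measured and differs from compound 2 in one place: benzyl in place of phenyl on a saturated chain carbon bound to an aromatic carbon. For the measured compounds named here, no measured pair shows this change, so nothing here sizes the step. The expected step of no change at the digits printed from compound 2 to compound 3 (within the scatter) is small, probably within the scatter, in either direction. Compound 3 is therefore estimated at 33%, with a range from 15% to 50%.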

Compound 3, a percentage reported as inhibition, at one concentration (the size of the read-out at that concentration, not a potency): 18%
Compound 3: the middle estimate sits 15 percentage points above what was measured, and the stated range covers the measured number.
By their numbers in this assay, from the lowest: compound 3; then compound 2; then compound 1.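

In this assay, benzyl in place of phenyl on a saturated chain carbon bound to an aromatic carbon gives a number 15 percentage points lower from compound 2 to compound 3 (beyond the scatter), so this position is sensitive to extending the chain. The fall rests on this single pair, and no wider pattern follows from it. Nothing available here accounts for the step. From the compounds shown here alone, it remains open whether a longer chain would lower the inhibition further. Going by these compounds, it is also open how an amine or a carboxylic acid at the end of this chain would read out.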